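The source may hold more compounds than are shown below. What is called first, only, known or untested is meant among the compounds shown, and "the series" means these compounds.

Measured in a functional assay on A549 cells (Homo sapiens) for cytotoxicity, read by MTT assay, with a stated time of 48 h; on this read-out higher numbers stand for weaker inhibition and lower numbers for stronger inhibition:
- Compound 1 `COc1cc([C@@H]2C[C@]2(CO)C(=O)Nc2ccccc2Cl)cc(OC)c1OC`: 4400 nM
- Compound 2 `CCOC(=O)C1(C(=O)NCc2ccccc2)CC1c1cc(OC)c(OC)c(OC)c1`: 79500 nM; > 100000 nM (2 entries)
- Compound 3 `CCOC(=O)[C@@]1(C(=O)Nc2ccccc2)C[C@@H]1c1cc(OC)c(OC)c(OC)c1`: > 100000 nM

Within the data shown here, compound 1, at 4400 nM, has the only single number in this small set. Compound 2 has several entries, 79500 nM; > 100000 nM (2 entries). Compound 3 gives > 100000 nM, which is a limit and not a number.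

The next compound to be tested is compound 4 `COc1cc([C@@H]2C[C@]2(CO)C(=O)NCc2ccc(C)cc2)cc(OC)c1OC`. It keeps the core of compound 1 but carries 4-methylbenzyl in place of 2-chlorophenyl on an amide-type nitrogen.

Among the measured compounds shown here, no measured pair isolates this swap, so any forecast for this assay is loose. Compound 1 at 4400 nM is the starting point, and compound 2 at 79500 nM; > 100000 nM (2 entries) shows how weak values in this set can run. A moderate weakening, beyond the usual scatter, is therefore expected. The estimated change is a 3.4-fold higher number from compound 1 to compound 4 (0.53 log units; beyond the scatter). Compound 4 is estimated at 15000 nM, with an expected range of 3000 nM to 80000 nM.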

Compound 4, half-maximal inhibitory concentration: 10500 nM
The estimate for compound 4 lay 1.4-fold (0.15 log units) above the measured number; the range from low to high includes it.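

Among these compounds, on the amide-type nitrogen of the core of compound 1, replacing 2-chlorophenyl with 4-methylbenzyl gives the first readable step in this assay: a 2.4-fold higher number from compound 1 to compound 4 (0.38 log units; beyond the scatter). The step is beyond the scatter but modest, so this position allows the whole aromatic group to be exchanged at only a limited cost in strength, and both compounds still give a single number rather than a limit. Nothing shown explains why the step has this size.

The swap removes the chlorine, adds a methyl and adds a carbon link to the ring all at once, so the compounds shown do not reveal which of these changes accounts for the weakening. Unsubstituted benzyl or 2-chlorobenzyl on the same nitrogen would help separate these changes, while a pyridylmethyl group would test a ring containing nitrogen.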